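Trifluoromethyl for Fluoro on a Second Core

The source may report more compounds than this note shows. Statements on the series, on what has been measured and on what is new or still open speak of the compounds shown alone.

Compound 1 `O=C1/C(=C/c2cccc(F)c2)CCc2cc(O)ccc21` and compound 2 `O=C1/C(=C/c2cccc(C(F)(F)F)c2)CCc2cc(O)ccc21` share one core, while compound 3 `O=C1/C(=C/c2ccccc2F)CCc2ccc(O)cc21` has the same atoms joined differently; the difference between the two cores is not broken down here. In a functional assay on RAW264.7 cells (Mus musculus) for inhibition (a higher number here means a weaker inhibitor, a lower number a stronger inhibitor), compound 1 gives 1230 nM, compound 2 gives 180 nM and compound 3 gives 1350 nM. The change trifluoromethyl in place of fluoro on an aromatic carbon brought a 6.8-fold lower number from compound 1 to compound 2 (0.83 log units; beyond the scatter). Compound 4 `O=C1/C(=C/c2ccccc2C(F)(F)F)CCc2ccc(O)cc21` carries the same kind of change on the core of compound 3, (trifluoromethyl in place of fluoro on an aromatic carbon), though the place is now ortho to a large group rather than meta to a large group. Going by the values given here, only one example of the change exists, so a somewhat smaller gain than a 6.8-fold lower number from compound 1 to compound 2 (0.83 log units; beyond the scatter) is expected, because compound 3 starts from 1350 nM, within the scatter of compound 1. On that basis the expected step is a 3.4-fold lower number from compound 3 to compound 4 (0.53 log units; beyond the scatter). Compound 4 is expected to give about 400 nM, between 150 nM and 1200 nM.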

Compound 4, half-maximal inhibitory concentration: 1020 nM
Compound 4: the middle estimate sits 2.6-fold (0.41 log units) below what was measured; the measured number falls inside the stated range.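

On the core of compound 3, trifluoromethyl in place of fluoro gave a 1.3-fold lower number from compound 3 to compound 4 (0.12 log units; within the scatter) in this assay, so the change did not carry over with the size it had on the core of compound 1. Set side by side, the two steps differ: the same change on two cores in this assay, a 6.8-fold lower number (0.83 log units; beyond the scatter) from compound 1 to compound 2 and a 1.3-fold lower number (0.12 log units; within the scatter) from compound 3 to compound 4, 5.2-fold (0.71 log units) apart, beyond the scatter of two such steps. This shows that the size of the step is not constant across these two cores, but with one pair on each core it does not show whether the core itself or the place of the group, ortho to a large group in compound 4, accounts for the gap.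

The compounds shown leave open how each core responds to the same change at the other place. They also leave open what a nitrile, a methoxy group or an amine would do in place of fluoro on either core.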